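A few compounds are considered here, and "the series" means these few. Any claim that something is new, unique, unknown or untested is made for them only; others in the source may bear on it.

Among the measured compounds shown here, compound 3 `Cc1ccc(C2CCN(CC(=O)Nc3cccc(C)c3)CC2)cc1` gives 3060 nM in a functional assay on cells for antagonist activity at D(4) dopamine receptor (Homo sapiens), read by TR-FRET and cAMP accumulation, with a stated time of 30 min (on this read-out higher numbers stand for weaker inhibition and lower numbers for stronger inhibition), the highest number of the three measured so far, though its gap to compound 1 `Cc1cccc(NC(=O)CCN2CCN(c3ccccn3)CC2)c1`, which gives 1630 nM in this assay, lies within the scatter. Compound 2 `Cc1ccc(C2CCN(CC(=O)Nc3cccc(C)c3)CC2)nc1` gives 453 nM in this assay, and the difference from there, taken as a step, is a 6.8-fold higher number from compound 2 to compound 3 (0.83 log units; beyond the scatter).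

Compound 4 `Cc1cccc(NC(=O)CN2CCC(c3ccccc3)CC2)c1` differs from compound 3 in one place: hydrogen in place of methyl on an aromatic carbon. The rest of the molecule stays as it is. For the measured compounds named here, none of the measured steps concerns this change; the only recorded step replaces one ring by another and says nothing about the methyl on the phenyl ring. There is therefore no measured basis for predicting a shift in either direction. For compound 4 the expected step in this assay is accordingly a 1.0-fold lower number from compound 3 to compound 4 (0.01 log units; within the scatter), which means no change beyond the scatter. Compound 4 is thus estimated at 3000 nM in this assay, with a range from 1200 nM to 7500 nM.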

Compound 4, half-maximal inhibitory concentration: 2 nM
Compound 4: middle estimate off by 1500-fold (3.18 log units), on the high side; measured number below the stated range.
By their numbers in this assay, from the lowest: compound 4; then compound 2; then compounds 1 and 3 (each within the scatter of the next).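

In this assay, the methyl on the aromatic carbon para to a large group proves decisive: going from 4-methylphenyl to phenyl gives a 1500-fold lower number from compound 3 to compound 4 (3.18 log units; beyond the scatter), so the loss of one carbon atom outweighs the ring exchange seen earlier. The unsubstituted phenyl also clearly outdoes the 5-methylpyridin-2-yl group, with a 230-fold lower number from compound 2 to compound 4 (2.36 log units; beyond the scatter), so that group recovers only part of the loss seen with 4-methylphenyl. No available evidence explains why so small a change has so large an effect.

Only hydrogen and methyl are shown on this carbon, so it remains open how a fluorine, a methoxy group or an amine would behave there. On these data alone, it is also open whether removing the methyl from the 5-methylpyridin-2-yl group of compound 2 would produce a similar drop.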